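The source may report more compounds than this note shows. Statements on the series, on what has been measured and on what is new or still open speak of the compounds shown alone.

In a functional assay on HCT-116 cells (Homo sapiens) for cytotoxicity, read by MTT assay, with a stated time of 72 h (on this read-out lower numbers stand for stronger inhibition and higher numbers for weaker inhibition), compound 3 (`COc1ccc(S(=O)(=O)c2nc3ccccc3nc2Nc2ccccc2)cc1`) gives 1260 nM, within the scatter of compound 1 (`O=S(=O)(c1ccccc1)c1nc2ccccc2nc1Nc1ccccc1`) at 1630 nM. Compound 2 (`Cc1ccc(S(=O)(=O)c2nc3ccccc3nc2Nc2ccc(F)cc2)cc1`) gives 10500 nM, beyond the scatter and higher than both. Compound 4 (`COc1ccc(S(=O)(=O)c2nc3ccccc3nc2Nc2ccc(F)cc2)cc1`) has fluoro in place of hydrogen on an aromatic carbon, (fluoro in place of hydrogen on an aromatic carbon). Among the measured compounds shown here, no measured step isolates this change. For the measured compounds named here, the only single-place step, a 1.3-fold lower number from compound 1 to compound 3 (0.11 log units; within the scatter), concerns methoxy in place of hydrogen and stays within the scatter. Going by the values given here, compound 2 at 10500 nM is the only measured compound carrying the 4-fluorophenyl group, but it differs from compound 3 in a second place too, so it is only partial evidence. A rise in this assay is expected, an estimated 4.0-fold higher number from compound 3 to compound 4 (0.60 log units; beyond the scatter). The estimate for compound 4 is 5000 nM, with an expected range of 1800 nM to 13000 nM.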

Compound 4, half-maximal inhibitory concentration: 2110 nM
Compound 4: middle estimate off by 2.4-fold (0.37 log units), on the high side; measured number inside the range.
By their numbers in this assay, from the lowest: compounds 3, 1 and 4 (each within the scatter of the next); then compound 2.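

In this assay, phenyl to 4-fluorophenyl comes with a 1.7-fold higher number from compound 3 to compound 4 (0.22 log units; within the scatter), so fluoro and hydrogen cannot be told apart at this place, para to a large group. With the 4-fluorophenyl group held constant, methoxy in place of methyl gives a 5.0-fold lower number from compound 2 to compound 4 (0.70 log units; beyond the scatter), which ties the high number of compound 2 to its methyl rather than to fluoro. No measured evidence on the compounds accounts for either step.

On these data alone, it remains open whether the methyl-to-methoxy step holds with an unsubstituted anilino group. Also open, as far as these compounds go, is whether chloro, an amine or a carboxylic acid would be tolerated in place of fluoro.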